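Methoxyphenyl oxazole benzoic acids at the vitamin D receptor

The source may report more compounds than this note shows. Statements on the series, on what has been measured and on what is new or still open speak of the compounds shown alone.

Compound 1 `COc1ccccc1-c1nc(C)c(COc2ccccc2C(=O)O)o1`: > 80000 nM
Compound 2 `COc1cccc(-c2nc(C)c(COc3ccccc3C(=O)O)o2)c1`: > 33000 nM
Compound 3 `COc1ccccc1-c1nc(C)c(COc2cccc(C(=O)O)c2)o1`: > 100000 nM

Of the compounds shown here, three have been tested in an assay on cells for antagonist activity at vitamin D3 receptor (Homo sapiens), read by a luciferase reporter; a higher number here means a weaker inhibitor, a lower number a stronger inhibitor. Compound 1 gives > 80000 nM in this assay, which is a limit of the assay rather than a number. Compound 2 gives > 33000 nM in this assay, again a limit. Compound 3 gives > 100000 nM in this assay, also a limit.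

Compound 2 differs from compound 1 by 3-methoxyphenyl in place of 2-methoxyphenyl on an aromatic carbon. The step that the two limits leave unreadable from compound 1 to compound 2 cannot be read because the limit of > 80000 nM in this assay, at which 1 of the 3 values shown sits, and the limit of > 33000 nM in this assay, at which 1 of the 3 values shown sits, are both limits of the assay.

The difference between the core of compound 1 and the core of compound 3 is not broken down here.

Compound 4 `COc1cccc(-c2nc(C)c(COc3cccc(C(=O)O)c3)o2)c1` has not yet been measured in this assay. It differs from compound 3 by 3-methoxyphenyl in place of 2-methoxyphenyl on an aromatic carbon, the same change that leads from compound 1 to compound 2. Since that earlier step is unreadable, the expectation for compound 4 rests only on the fact that all three measured compounds sit at limits, including compound 3 with the limit of > 100000 nM in this assay, at which 1 of the 3 values shown sits. The step from compound 3 to compound 4 is therefore estimated as a number no higher from compound 3 to compound 4 (the limit leaves the size open). Compound 4 is expected to give about 100000 nM in this assay, estimated to lie between 30000 nM and 300000 nM, most likely reported as a limit rather than a number.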

Compound 4, half-maximal inhibitory concentration: 33100 nM
For compound 4 the middle estimate is 3.0-fold (0.48 log units) above the measured one, and the stated range covers the measured number.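

In this assay, placing 3-methoxyphenyl in place of 2-methoxyphenyl on the core of compound 3 gives an at least 3.0-fold lower number from compound 3 to compound 4 (0.48 log units; beyond the scatter), and compound 4 gives 33100 nM, which is a measured number and the only one among the compounds shown. For the compounds shown here, the size of this step is only a lower bound, because the starting value of compound 3 is a limit of the assay and not a number: the limit of > 100000 nM in this assay, at which 1 of the 4 values shown sits. The result therefore shows that the change lowers the number on this one core, but it does not show that the change carries over to the core of compound 1, where the same step from compound 1 to compound 2 cannot be read, and so there is no second readable step to set beside it.

The compounds shown leave open how far the number of compound 3 lies beyond its limit, and so how large the step on this core really is. They also leave open what an ethoxy group in place of the methoxy group, a longer chain in place of the methyl group on the ring, or an amide in place of the carboxylic acid would do in this assay.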